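This account rests on a few compounds, and the source may have more. Where it says the series, first, only, none or still open, it means among the compounds named here.

Measured compounds:
Compound 1 `Cc1c(OCCCCOc2ccc(C(=O)O)cc2F)ccc(C(=O)CC2CCCC2)c1O`: in an assay on HEK293 cells for positive allosteric modulation of metabotropic glutamate receptor 3 (Rattus norvegicus), read by thallium flux, with a stated time of 2.5 min (on this read-out lower numbers stand for an effect already at smaller amounts and higher numbers for an effect only at larger amounts of compound), compound 1 gives only a limit, > 10000 nM.
Compound 2 `Cc1c(OCCCCOc2ccc(C(=O)O)cc2Cl)ccc(C(=O)CC2CCCC2)c1O`: in this assay compound 2 gives only a limit, > 10000 nM.

Compound 2 therefore stands at the limit of this assay, not at a measured number, and the same holds for every value shown, since both of the two sit at that limit (the limit of > 10000 nM in this assay, at which 2 of the 2 values shown sit). For the measured compounds named here, the single measured step is a step that the two limits leave unreadable from compound 1 to compound 2. Both of its ends are limits, and its size is not readable.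

Compound 3 `Cc1cc(C(=O)O)ccc1OCCCCOc1ccc(C(=O)CC2CCCC2)c(O)c1C` differs from compound 2 by methyl in place of chloro on an aromatic carbon. Going by the values given here, no measured step gives a readable size for a change of this kind, so the only guide is that compound 2 itself shows no effect up to the limit. The estimated step is a step that the limit leaves unreadable from compound 2 to compound 3, meaning nothing beyond the usual scatter. Compound 3 is expected at 15000 nM, within 3000 nM to 60000 nM, most likely again reported only as a limit.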

Compound 3, half-maximal effective concentration: > 10000 nM
Compound 3: a limit, no number (the forecaster's own chance of this, stated with the estimate: 75%); the middle value lies beyond the limit too.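

No new step can be read, as compound 1, compound 2 and compound 3 all stand at a limit rather than a number. Left open is whether fluoro, chloro or methyl on this aromatic carbon makes any difference in this assay.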